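The source may hold more compounds than are shown below. What is called first, only, known or untested is meant among the compounds shown, and "the series" means these compounds.

Going by the values given here, in a functional assay on MCF7 cells (Homo sapiens) for inhibition (on this read-out lower numbers stand for stronger inhibition and higher numbers for weaker inhibition), three compounds have numbers so far. Compound 1 `Oc1cccc(-c2nc3cc(F)ccc3s2)c1` gives 570 nM, compound 2 `COc1ccccc1-c1nc2cc(F)ccc2o1` gives 360 nM, and compound 3 `COc1ccc(-c2nc3cc(F)ccc3o2)cc1OC` gives 830 nM. Compound 1 thus stands within the usual scatter of both the others, and these three values cannot be told apart.

Compound 4 `Cc1ccc(-c2nc3cc(F)ccc3s2)cc1O` departs from compound 1 in one place: methyl in place of hydrogen on an aromatic carbon. A methyl takes the place of a hydrogen on an aromatic carbon of a six-membered aromatic ring of carbon only, ortho to a hydroxy group and para to a large group. Among the compounds with values here, no measured pair in this set differs in only one place, so the data offer no direct guide to the size of such a step. Nothing beyond the scatter is therefore expected in this assay, in either direction, and the estimated change is only a 1.2-fold lower number from compound 1 to compound 4 (0.07 log units; within the scatter). Compound 4 is expected to give about 480 nM, with an estimated range of 170 nM to 1300 nM.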

Compound 4, half-maximal inhibitory concentration: 500 nM
The estimate for compound 4 lay 1.0-fold (0.02 log units) below the measured number, and the stated range covers the measured number.
By their numbers in this assay, from the lowest: compounds 2, 4, 1 and 3 (each within the scatter of the next, the first and the last beyond it).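

Going by these compounds alone, this is the first step in the set that can be read, and it is small: in this assay methyl in place of hydrogen on an aromatic carbon, ortho to a hydroxy group and para to a large group, gives a 1.1-fold lower number from compound 1 to compound 4 (0.06 log units; within the scatter) and so does not move the number beyond the scatter. At this one position, with the hydroxy group kept, the added methyl therefore leaves the inhibition of compound 1 indistinguishable from before. No measurement at hand bears on why this step is so small.

Going by these compounds, whether another group at this position, such as ethyl, a chlorine atom or an amine, would also stay within the scatter remains open. Also open, on these data alone, is what replacing the hydroxy group itself with a methoxy group or a carboxylic acid would do to the number of compound 1.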